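Hydroxy to nitro on the shared core

The compounds below may be only part of what the source reports. "The series", "measured", "known", "first", "only" and "open" are said of these compounds alone.

Compound 1 `COc1ccc(/C(F)=C(/F)c2cc(OC)c(OC)c(OC)c2)cc1N`: 7.3 nM
Compound 2 `COc1ccc(/C(F)=C(/F)c2cc(OC)c(OC)c(OC)c2)cc1O`: 3 nM
Compound 3 `COc1ccc(/C(F)=C(/F)c2cc(OC)c(OC)c(OC)c2)cc1[N+](=O)[O-]`: not yet measured

In a functional assay on NCI-H460 cells (Homo sapiens) for cytotoxicity, read by sulforhodamine B assay, with a stated time of 72 h (a higher number here means a weaker inhibitor, a lower number a stronger inhibitor), compound 2 stands lowest of the two measured compounds at 3 nM. The next change puts nitro in place of hydroxy on an aromatic carbon. Among the compounds with values here, only one measured step bears on it, the modest 2.4-fold lower number from compound 1 to compound 2 (0.39 log units; beyond the scatter), which also changes the group on this carbon. Within the data shown here, no measured compound carries nitro, so that step gives only a rough scale. A moderate rise in this assay is expected, larger than that step. The expected step is a 6.7-fold higher number from compound 2 to compound 3 (0.82 log units; beyond the scatter). The estimate for compound 3 is 20 nM, with an expected range of 5 nM to 90 nM.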

Compound 3, half-maximal inhibitory concentration: 1170 nM
Estimate against measurement, compound 3: 59-fold (1.77 log units) below; measured number outside the range, above it.
By their numbers in this assay, from the lowest: compound 2; then compound 1; then compound 3.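

In this assay, the group on this carbon, ortho to a methoxy group, can matter far more than the amino-to-hydroxy step suggested, as nitro brings large rises from both neighbours (a 390-fold higher number from compound 2 to compound 3 (2.59 log units; beyond the scatter)) and (a 160-fold higher number from compound 1 to compound 3 (2.20 log units; beyond the scatter)). This position is therefore not indifferent to its substituent, and nitro stands well apart from hydroxy and amino. Nothing at hand explains the loss.

Three groups cannot show which feature of nitro matters. A carboxylic acid, a methyl or a fluorine on this carbon would test how far the loss extends.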